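Ethyl for hydrogen on two oxygens of a shared core

The source may hold more compounds than are shown below. What is called first, only, known or untested is meant among the compounds shown, and "the series" means these compounds.

Measured compounds:
compound 1 `O=C(O)c1cnc(-c2ccccc2O)[nH]c1=O`: > 5 mg/kg
compound 2 `CCOc1ccccc1-c1ncc(C(=O)O)c(=O)[nH]1`: 0.5 mg/kg
compound 3 `Cn1c(-c2ccccc2)ncc(C(=O)O)c1=O`: 50 mg/kg

The three measured compounds were tested in a functional assay on the whole organism (strain Sprague-Dawley) for inhibition, with Rattus norvegicus as the target, with a stated time of 10 min; a lower number here means that less compound is needed, a higher number that more compound is needed for the effect. Compound 1 `O=C(O)c1cnc(-c2ccccc2O)[nH]c1=O` reaches only a limit of this assay, > 5 mg/kg, so no number is known for it. Compound 2 `CCOc1ccccc1-c1ncc(C(=O)O)c(=O)[nH]1` gives 0.5 mg/kg in this assay. Compound 3 `Cn1c(-c2ccccc2)ncc(C(=O)O)c1=O` gives 50 mg/kg, the highest number of the two that are numbers, and a higher one than compound 2. The difference between the core of compound 1 and that of compound 3 is not broken down here.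

The change from compound 1 to compound 2 is ethyl in place of hydrogen on an oxygen on an aromatic ring, and it made an at least 10-fold lower number from compound 1 to compound 2 (1.00 log units; beyond the scatter). The same kind of change leads from compound 3 to compound 4 `CCOC(=O)c1cnc(-c2ccccc2)n(C)c1=O`, which is still unmeasured: ethyl in place of hydrogen on an oxygen next to a carbonyl group. The place differs: in compound 2 the ethyl sits on an oxygen on an aromatic ring whose other neighbours are an aromatic carbon, whereas in compound 4 it sits on an oxygen next to a carbonyl group whose other neighbours are the carbonyl carbon. Among the measured compounds shown here, because the only measured change of this kind sits in a different place and one end of it is the limit (the limit of > 5 mg/kg in this assay, at which 1 of the 3 values shown sits), the earlier step is a weak guide. Compound 4 is therefore expected to give 20 mg/kg in this assay, between 3 mg/kg and 100 mg/kg, an expected step of a 2.5-fold lower number from compound 3 to compound 4 (0.40 log units; beyond the scatter).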

Compound 4, dose for 50% inhibition: > 5 mg/kg
Compound 4 ended at the assay's limit (the forecaster's own chance of this, stated with the estimate: 20%); the middle value lies beyond the limit too.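

Compound 4 gives > 5 mg/kg in this assay, which is a limit of the assay and not a number. Among the compounds shown here, no step from compound 3 to compound 4 can be read because of this limit: the limit of > 5 mg/kg in this assay, at which 2 of the 4 values shown sit.

The compounds shown leave open whether ethyl in place of hydrogen on an oxygen next to a carbonyl group lowers or raises the number in this assay at all.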